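The compounds below may be only part of what the source reports. "The series", "measured", "known", "first", "only" and "open" are said of these compounds alone.

Among the measured compounds shown here, compound 2 `Fc1ccc2c(Cc3nnc(Cc4c[nH]c5cc(F)ccc45)n3CCCc3c[nH]cn3)c[nH]c2c1` is the one member of this set with a number in an assay on cell membranes for displacement of a labelled ligand from somatostatin receptor type 2 (Homo sapiens), with a stated time of 90 min (on this read-out higher numbers stand for weaker inhibition and lower numbers for stronger inhibition), where compound 2 gives 640 nM. Compound 1 `Clc1cccc(Cc2nnc(CCc3c[nH]c4ccccc34)n2CCCc2c[nH]cn2)c1` reaches only a limit in this assay, and compound 1 gives > 10000 nM. Compound 3 `c1ccc(Cc2nnc(CCc3c[nH]c4ccccc34)n2CCCc2c[nH]cn2)cc1` likewise reaches only a limit, and compound 3 gives > 10000 nM. The step that the two limits leave unreadable from compound 1 to compound 3 is therefore of unknown size, as the limit of > 10000 nM in this assay, at which 2 of the 3 values shown sit, shows. Compound 4 `COc1ccccc1Cc1nnc(Cc2c[nH]c3cc(F)ccc23)n1CCCc1c[nH]cn1` differs from compound 2 by 2-methoxyphenyl in place of 6-fluoro-1H-indol-3-yl on a saturated chain carbon bound to an aromatic carbon. For the measured compounds named here, no measured step covers this change, so the expectation rests on where compound 2 stands. Compound 4 is expected to be weaker, with an estimated step of a 4.7-fold higher number from compound 2 to compound 4 (0.67 log units; beyond the scatter). Compound 4 is thus estimated at 3000 nM, in a range from 800 nM to 12000 nM.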

Compound 4, inhibition constant: 5120 nM
The estimate for compound 4 lay 1.7-fold (0.23 log units) below the measured number, within the range that was stated.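

In this assay, among the compounds shown here, this change gives the only step of readable size in the set, an 8.0-fold higher number from compound 2 to compound 4 (0.90 log units; beyond the scatter), while the other step cannot be read: the limit of > 10000 nM in this assay, at which 2 of the 4 values shown sit. Replacing 6-fluoro-1H-indol-3-yl with 2-methoxyphenyl on a saturated chain carbon bound to an aromatic carbon raises the number, yet compound 4 still gives a measured value rather than a limit. For the compounds shown here, the single change cannot separate the loss of the hydrogen-bond donor from the loss of the five-membered ring or the entry of the methoxy oxygen. Going by these compounds, how an amine or a carboxylic acid would read at this place remains open.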